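Compound 3 to compound 4: a new group on the oxygen

A few compounds are considered here, and "the series" means these few. Any claim that something is new, unique, unknown or untested is made for them only; others in the source may bear on it.

Compound 3 `COc1cccc(C(=O)Oc2ccc3c(=O)c(-c4cc(OC)c(OC)cc4OC)coc3c2)c1` gives only a limit in a functional assay on HUVEC cells (Homo sapiens) for antiproliferative activity, read by MTT assay, with a stated time of 24 h (a higher number here means a weaker inhibitor, a lower number a stronger inhibitor), at > 10000 nM. Compound 2 `C=CCOc1ccc2c(=O)c(-c3cc(OC)c(OC)cc3OC)coc2c1` likewise gives only a limit, at > 10000 nM. Compound 1 `COc1cc(OC)c(-c2coc3cc(OCC=C(C)C)ccc3c2=O)cc1OC` alone gives a number, at 3800 nM. Compound 3 therefore stands at the limit of > 10000 nM in this assay, at which 2 of the 3 values shown sit, and the two limits leave a step that the two limits leave unreadable from compound 2 to compound 3.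

Compound 4 `COc1cc(OC)c(-c2coc3cc(OCc4ccccc4F)ccc3c2=O)cc1OC` differs from compound 3 in one place: 2-fluorobenzyl in place of (3-methoxyphenyl)carbonyl on an oxygen on an aromatic ring. This puts 2-fluorobenzyl in place of (3-methoxyphenyl)carbonyl on an oxygen on an aromatic ring.

Among the compounds with values here, two measured steps bear on this change. (3-Methoxyphenyl)carbonyl in place of 3-methylbut-2-en-1-yl on the same oxygen gives an at least 2.6-fold higher number from compound 1 to compound 3 (0.42 log units; beyond the scatter), so the group held there can matter. Vinyl in place of 2-methylprop-1-en-1-yl on a saturated chain carbon gives an at least 2.6-fold higher number from compound 1 to compound 2 (0.42 log units; beyond the scatter), so a group without that carbonyl does not guarantee a measurable number, as compound 2 shows. Neither step involves a benzyl group.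

A modest move toward a lower number is therefore expected in this assay, and a further reading at the limit remains quite possible. The expected step is an at least 1.6-fold lower number from compound 3 to compound 4 (0.22 log units; that floor lies within the scatter). For compound 4 the estimate is 6000 nM, with an expected range of 1500 nM to 20000 nM.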

Compound 4, half-maximal inhibitory concentration: 4300 nM
Beside the measured number, compound 4's estimate is 1.4-fold (0.14 log units) above it; measured number inside the range.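

In this assay, 2-fluorobenzyl on this oxygen gives a measured number where (3-methoxyphenyl)carbonyl gave only a limit, with an at least 2.3-fold lower number from compound 3 to compound 4 (0.36 log units; beyond the scatter). 2-Fluorophenyl in place of vinyl on the saturated chain carbon bound to the oxygen also moves the reading off the limit, with an at least 2.3-fold lower number from compound 2 to compound 4 (0.36 log units; beyond the scatter), so the allyl group of compound 2 and the (3-methoxyphenyl)carbonyl group of compound 3 now both stand apart from 2-fluorobenzyl. 2-Fluorophenyl in place of 2-methylprop-1-en-1-yl gives a 1.1-fold higher number from compound 1 to compound 4 (0.05 log units; within the scatter), which lies within the scatter, so two quite different groups without a carbonyl, 3-methylbut-2-en-1-yl and 2-fluorobenzyl, now give values that cannot be told apart, while allyl, which also lacks a carbonyl, goes against any simple rule based on that feature.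

The compounds shown leave open how an unsubstituted benzyl group, or a longer chain ending in an amine or a carboxylic acid, would read on this oxygen. From the compounds shown here alone, the true size of the steps from the two compounds held at a limit also stays open: the limit of > 10000 nM in this assay, at which 2 of the 4 values shown sit.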